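This account rests on a few compounds, and the source may have more. Where it says the series, first, only, none or still open, it means among the compounds named here.

Measured so far in an ADME assay on HEp-2 cells (Homo sapiens) for cytotoxicity; on this read-out lower numbers stand for higher toxicity in this test and higher numbers for lower toxicity in this test
- compound 1 `CC(C)CCn1c(Cn2c(=O)n(C(C)C)c3ccccc32)nc2cc(CN(C)C)ccc21` at 5650 nM
- compound 2 `CC(C)CCn1c(Cn2c(=O)n(C(C)C)c3ccccc32)nc2cc(CO)ccc21` at 31600 nM

Compound 2 stands higher of the two at 31600 nM in these notes. Compound 3 `CC(C)CCn1c(Cn2c(=O)n(C(C)C)c3ccccc32)nc2cc(CF)ccc21` differs from compound 2 by fluoro in place of hydroxy on a saturated chain carbon bound to an aromatic carbon and so carries fluoro in place of hydroxy on a saturated chain carbon bound to an aromatic carbon. Within the data shown here, the one measured step at this place is a 5.6-fold higher number from compound 1 to compound 2 (0.75 log units; beyond the scatter) and it was modest, with hydroxy entering rather than leaving. Among the measured compounds shown here, no measured compound carries fluoro, so only a small move toward a lower number is expected in this assay here. The expected step is a 1.6-fold lower number from compound 2 to compound 3 (0.20 log units; within the scatter) in size. Compound 3 is estimated at 20000 nM with an expected range of 8000 nM to 50000 nM on this reading.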

Compound 3, half-maximal cytotoxic concentration: 37300 nM
Compound 3: middle estimate off by 1.9-fold (0.27 log units), on the low side, within the range that was stated.
By their numbers in this assay, from the lowest: compound 1; then compounds 2 and 3 (each within the scatter of the next).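

In this assay fluoro in place of hydroxy gives a 1.2-fold higher number from compound 2 to compound 3 (0.07 log units; within the scatter) even though the hydrogen-bond donor and acceptor of hydroxy are gone, so at this carbon hydroxy and fluoro cannot be told apart. Fluoro in place of dimethylamino gives a 6.6-fold higher number from compound 1 to compound 3 (0.82 log units; beyond the scatter) and thus repeats the modest step seen with hydroxy, leaving compound 1 alone apart from the other two. On these data alone, whether a primary amine, a carboxylic acid or a longer chain on this carbon would side with dimethylamino or with the hydroxy and fluoro pair stays open. No measurement at hand accounts for these differences.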